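Swapping bromo for methyl on the amide aryl ring

This account rests on a few compounds, and the source may have more. Where it says the series, first, only, none or still open, it means among the compounds named here.

Measured compounds:
- compound 1, `CCCC(=O)Nc1c(C(O)(C(F)(F)F)C(F)(F)F)ccc2ccccc12`: 131 nM
- compound 2, `O=C(Nc1c(C(O)(C(F)(F)F)C(F)(F)F)ccc2ccccc12)C1CCC1`: 45 nM
- compound 3, `O=C(Nc1c(C(O)(C(F)(F)F)C(F)(F)F)ccc2ccccc12)c1cccc(Br)c1`: 80 nM

All three compounds share one core and differ only in the group on the carbonyl carbon of the amide. In an assay on LtK cells with ATP-sensitive inward rectifier potassium channel 11 (Homo sapiens) as the target (on this read-out higher numbers stand for an effect only at larger amounts of compound and lower numbers for an effect already at smaller amounts), compound 3, with its 3-bromophenyl group, stands second highest of the three numbers; its nearest neighbour is compound 1, and the gap between them is within the scatter, as is the gap to compound 2. Among the steps, only a 2.9-fold lower number from compound 1 to compound 2 (0.46 log units; beyond the scatter) is beyond the scatter, while a 1.6-fold lower number from compound 1 to compound 3 (0.21 log units; within the scatter) and a 1.8-fold higher number from compound 2 to compound 3 (0.25 log units; within the scatter) are not.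

The next compound, compound 4, `Cc1cccc(C(=O)Nc2c(C(O)(C(F)(F)F)C(F)(F)F)ccc3ccccc23)c1`, keeps everything of compound 3 except one change: methyl in place of bromo on an aromatic carbon, meta to a large group. Among the compounds with values here, no measured step bears directly on this exchange, since every step so far replaces the whole group on the carbonyl carbon rather than a single atom on that group. Within the data shown here, the only guidance is that two of three steps between these neighbours stayed within the scatter, so a step in this assay beyond the scatter is not expected, in either direction, and the expected step is a 1.1-fold higher number from compound 3 to compound 4 (0.05 log units; within the scatter). For compound 4 the estimated value is therefore 90 nM, with a range from 40 nM to 200 nM.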

Compound 4, half-maximal effective concentration: 23 nM
Estimate against measurement, compound 4: 3.9-fold (0.59 log units) above; the measured number lies below the stated range.
By their numbers in this assay, from the lowest: compounds 4, 2, 3 and 1 (each within the scatter of the next, the first and the last beyond it).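

On this aromatic carbon, meta to a large group, exchanging one heavy atom for another changes the result in this assay, even though the count of rings, hydrogen-bond donors, hydrogen-bond acceptors and net charge stays the same: bromo to methyl gives a 3.5-fold lower number from compound 3 to compound 4 (0.54 log units; beyond the scatter). The earlier steps shown here replaced the whole group on the carbonyl carbon, so they could not show that a single substituent on the aryl ring can move the number beyond the scatter. With methyl at this place, the aryl amide also separates from the propyl amide, with a 5.7-fold lower number from compound 1 to compound 4 (0.76 log units; beyond the scatter), whereas the comparison with the cyclobutyl amide, a 2.0-fold lower number from compound 2 to compound 4 (0.29 log units; within the scatter), gives no basis for ranking those two, and nothing available explains why the exchange has this effect.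

The compounds shown leave open how an unsubstituted phenyl ring, or a chloro, methoxy or amino group at this place, would compare with methyl and bromo. They also leave open whether a longer chain, such as ethyl or propyl, would keep the number as low as methyl does.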